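Second chloro on the aryl of compound 2: an estimate

The source may report more compounds than this note shows. Statements on the series, on what has been measured and on what is new or still open speak of the compounds shown alone.

Compound 1 `Cc1nc(Nc2ccc(Cl)cc2)sc1C(=O)/C=C/c1ccccc1` and compound 2 `Cc1nc(Nc2cccc(Cl)c2)sc1C(=O)/C=C/c1ccccc1` share one core. In a functional assay on BGC-823 cells (Homo sapiens) for cytotoxicity, read by MTT assay (a lower number here means a stronger inhibitor, a higher number a weaker inhibitor), compound 1 gives only a limit, > 25000 nM. In this assay compound 2 likewise gives only a limit, > 25000 nM. The step that the two limits leave unreadable from compound 1 to compound 2 is therefore unreadable, and the limit of > 25000 nM in this assay, at which 2 of the 2 values shown sit, is all the two values show. Compound 3 `Cc1nc(Nc2ccc(Cl)c(Cl)c2)sc1C(=O)/C=C/c1ccccc1` differs from compound 2 by chloro in place of hydrogen on an aromatic carbon. Among the compounds with values here, no measured step bears readably on this change, so nothing beyond the scatter is expected in either direction. Compound 3 is expected to give 30000 nM (range 8000 nM to 120000 nM). The step that the limit leaves unreadable from compound 2 to compound 3 is thus estimated as small, with a limit again the likeliest outcome.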

Compound 3, half-maximal inhibitory concentration: 10600 nM
The estimate for compound 3 lay 2.8-fold (0.45 log units) above the measured number, and the stated range covers the measured number.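

In this assay, within the data shown here, the 3,4-dichlorophenyl group gives the first readable number of the series, with an at least 2.3-fold lower number from compound 2 to compound 3 (0.37 log units; beyond the scatter) and an at least 2.3-fold lower number from compound 1 to compound 3 (0.37 log units; beyond the scatter). Neither 3-chlorophenyl nor 4-chlorophenyl alone leaves the limit, so the gain in these compounds goes with the two chloro groups together. The step from compound 1 to compound 2 cannot be read, and the other two steps are bounds only: the limit of > 25000 nM in this assay, at which 2 of the 3 values shown sit.

Open, on these data alone, is whether a methyl, a methoxy or a trifluoromethyl group in place of the added chloro would carry a similar step. As far as these compounds go, whether an amine there would do the same also stays open.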